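The source may report more compounds than this note shows. Statements on the series, on what has been measured and on what is new or still open speak of the compounds shown alone.

Measured in a functional assay on HeLa S3 cells (Homo sapiens) for antiproliferative activity, read by XTT assay, with a stated time of 72 h; a higher number here means a weaker inhibitor, a lower number a stronger inhibitor:
- compound 1 `COc1ncnc2c1c(-c1cccs1)cn2[C@@H]1O[C@H](CO)[C@@H](O)[C@H]1O` gives 1760 nM
- compound 2 `C#Cc1cn([C@@H]2O[C@H](CO)[C@@H](O)[C@H]2O)c2ncnc(OC)c12` gives 1730 nM
- compound 3 `COc1ncnc2c1c(-c1cc3ccccc3o1)cn2[C@@H]1O[C@H](CO)[C@@H](O)[C@H]1O` gives 9240 nM

Compound 3 stands highest of the three numbers; its nearest neighbours are compound 1 and compound 2, which sit at the same level as each other. Compound 4 `COc1ncnc2c1c(-c1ccco1)cn2[C@@H]1O[C@H](CO)[C@@H](O)[C@H]1O` differs from compound 3 by furan-2-yl in place of 1-benzofuran-2-yl on an aromatic carbon. Within the data shown here, the steps that bear on this are a 5.3-fold higher number from compound 1 to compound 3 (0.72 log units; beyond the scatter) and a 5.3-fold higher number from compound 2 to compound 3 (0.73 log units; beyond the scatter); both show the 1-benzofuran-2-yl group raising the number beyond the scatter. The furan-2-yl of compound 4 is a single five-membered ring, as is the thiophen-2-yl of compound 1, so a downward step roughly reversing that rise is expected, a 4.6-fold lower number from compound 3 to compound 4 (0.66 log units; beyond the scatter). Compound 4 is therefore estimated at 2000 nM in this assay, with a range from 900 nM to 4500 nM.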

Compound 4, half-maximal inhibitory concentration: 1020 nM
Compound 4: the middle estimate sits 2.0-fold (0.29 log units) above what was measured, within the range that was stated.
By their numbers in this assay, from the lowest: compounds 4, 2 and 1 (each within the scatter of the next); then compound 3.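

In this assay, the six-membered aromatic ring of the 1-benzofuran-2-yl group marks the difference at this position: losing it gives the largest step in the series (a 9.1-fold lower number from compound 3 to compound 4 (0.96 log units; beyond the scatter)). Furan-2-yl is not separated from thiophen-2-yl (a 1.7-fold lower number from compound 1 to compound 4 (0.24 log units; within the scatter)) or from ethynyl (a 1.7-fold lower number from compound 2 to compound 4 (0.23 log units; within the scatter)), so three different groups now share one level, with only compound 3 apart. Nothing measured on hand explains this step.

On these data alone, whether an amine, a carboxylic acid or a longer chain on this carbon stays at that level remains open. So does whether a phenyl ring behaves like furan-2-yl or like 1-benzofuran-2-yl.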